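Quinoline amide series: aryl group at the ring-nitrogen position

The source may report more compounds than this note shows. Statements on the series, on what has been measured and on what is new or still open speak of the compounds shown alone.

Compound 3 `COc1cccc(-c2cc(C(=O)Nc3ccc(Oc4ccnc5cc(OCCCN6CCCCC6)c(OC)cc45)c(F)c3)c3cc(F)ccc3n2)c1` is the weakest of the three measured compounds: in a functional assay on NCI-H460 cells (Homo sapiens) for cytotoxicity, read by MTT assay, with a stated time of 72 h (a higher number here means a weaker inhibitor, a lower number a stronger inhibitor), compound 3 gives 1000 nM, while compound 1 `COc1cccc(-c2cc(C(=O)Nc3ccc(Oc4ccnc5cc(OCCCN6CCCCC6)c(OC)cc45)c(F)c3)c3ccccc3n2)c1` gives 210 nM and compound 2 `COc1cc2c(Oc3ccc(NC(=O)c4cc(-c5ccccc5)nc5ccc(F)cc45)cc3F)ccnc2cc1OCCCN1CCCCC1` gives 32 nM. The two steps that lead to compound 3 both raise the number, a 4.8-fold higher number from compound 1 to compound 3 (0.68 log units; beyond the scatter) and a 31-fold higher number from compound 2 to compound 3 (1.49 log units; beyond the scatter).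

Compound 4 `COc1cc2c(Oc3ccc(NC(=O)c4cc(-c5ccc(C)cc5)nc5ccc(F)cc45)cc3F)ccnc2cc1OCCCN1CCCCC1` carries 4-methylphenyl in place of 3-methoxyphenyl on an aromatic carbon, on the aromatic carbon next to the ring nitrogen of the shared core. The step that bears directly on this change is a 31-fold higher number from compound 2 to compound 3 (1.49 log units; beyond the scatter), which concerns the same methoxy group now removed; its size was large. The step of a 4.8-fold higher number from compound 1 to compound 3 (0.68 log units; beyond the scatter) concerns the fluoro on the shared core, which the change does not touch, and does not speak to the change itself. For the measured compounds named here, no measured step tells what a methyl on the para position of the pendant phenyl does, so that part is uncertain. The removal of the methoxy is therefore expected to lower the number for compound 4 by a large step, a 20-fold lower number from compound 3 to compound 4 (1.30 log units; beyond the scatter). Compound 4 is estimated at 50 nM, with a range from 15 nM to 200 nM.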

Compound 4, half-maximal inhibitory concentration: 260 nM
The estimate for compound 4 lay 5.2-fold (0.72 log units) below the measured number, outside the stated range (above it).
By their numbers in this assay, from the lowest: compound 2; then compounds 1 and 4 (each within the scatter of the next); then compound 3.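

In this assay, 4-methylphenyl on this aromatic carbon next to the ring nitrogen gives a lower number than 3-methoxyphenyl (a 3.8-fold lower number from compound 3 to compound 4 (0.59 log units; beyond the scatter)), so the higher number of compound 3 is not shared in full by every substituted phenyl. It does not match the plain phenyl of compound 2, however (an 8.1-fold higher number from compound 2 to compound 4 (0.91 log units; beyond the scatter)), so both substituted phenyl groups shown here give higher numbers than the unsubstituted ring. No evidence is available that explains the size of either step.

The change from compound 3 to compound 4 swaps both the substituent and its place on the phenyl, and the compounds shown leave the contribution of each unresolved. Also open, as far as these compounds go, is how this position responds to a phenyl bearing an amine or a carboxylic acid, or to a saturated ring such as cyclohexyl in place of the phenyl.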